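The source may hold more compounds than are shown below. What is called first, only, known or untested is meant among the compounds shown, and "the series" means these compounds.

Measured in an assay on isolated protein for inhibition of steroid 17-alpha-hydroxylase/17,20 lyase (Homo sapiens); on this read-out higher numbers stand for weaker inhibition and lower numbers for stronger inhibition:
compound 1 `CC(=O)c1ccc2cc(C(O)(c3c[nH]cn3)C(C)C)ccc2c1` gives 28 nM
compound 2 `CC(C)C(O)(c1ccc2cc(C(N)=O)ccc2c1)c1c[nH]cn1` gives 30 nM

For the measured compounds named here, of these two numbers, the one for compound 2 is the larger, but only by a 1.1-fold higher number from compound 1 to compound 2 (0.03 log units; within the scatter), within the scatter. Compound 3 `CNC(=O)Nc1ccc2cc(C(O)(c3c[nH]cn3)C(C)C)ccc2c1` carries (methylcarbamoyl)amino in place of carbamoyl on an aromatic carbon. Going by the values given here, the single measured step, a 1.1-fold higher number from compound 1 to compound 2 (0.03 log units; within the scatter), altered a group on a carbonyl carbon and gives no guide to a (methylcarbamoyl)amino group. The expected step is therefore a 1.3-fold higher number from compound 2 to compound 3 (0.12 log units; within the scatter), nothing beyond the scatter. For compound 3 the estimate in this assay is 40 nM, with a range from 12 nM to 130 nM.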

Compound 3, half-maximal inhibitory concentration: 36 nM
For compound 3 the middle estimate is 1.1-fold (0.05 log units) above the measured one; low and high end bracket the measured number.
By their numbers in this assay, from the lowest: compounds 1, 2 and 3 (each within the scatter of the next).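

On this aromatic carbon, (methylcarbamoyl)amino brings 5 heavy atoms where carbamoyl has 3 and 2 hydrogen-bond donors where carbamoyl has 1, yet the numbers in this assay lie within the scatter of each other, with a 1.2-fold higher number from compound 2 to compound 3 (0.08 log units; within the scatter). Set against acetyl, the same group gives a 1.3-fold higher number from compound 1 to compound 3 (0.11 log units; within the scatter), so all three groups shown here at this position sit within the scatter. Nothing available explains this tolerance. Still open, as far as these compounds go, is whether an amine or a carboxylic acid here would fall outside that scatter. From the compounds shown here alone, a longer chain in place of the methyl of (methylcarbamoyl)amino is equally open.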